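From an Acetamidoethyl Amine to a Carboxy-Bearing Amine

The source may report more compounds than this note shows. Statements on the series, on what has been measured and on what is new or still open speak of the compounds shown alone.

For the measured compounds named here, in a functional assay on MC-38 cells (Mus musculus) for antiproliferative activity, read by CCK-8 assay, with a stated time of 48 h (on this read-out lower numbers stand for stronger inhibition and higher numbers for weaker inhibition), compound 2 `COc1ccc(/C=C\c2cc(OC)c(OC)c(OC)c2)cc1OCc1ccc(CNCCNC(C)=O)cc1` gives 1800 nM, the lower of the two numbers so far, while compound 1 `COc1ccc(/C=C\c2cc(OC)c(OC)c(OC)c2)cc1OCc1ccc(CN2CCCCC2C(=O)O)cc1` gives 5400 nM. Compound 3 `COc1ccc(/C=C\c2cc(OC)c(OC)c(OC)c2)cc1OCc1ccc(CN[C@H](C(=O)O)[C@@H](C)O)cc1` has 1-carboxy-2-hydroxypropyl in place of 2-acetamidoethyl on an amine nitrogen. Going by the values given here, the one measured step, a 3.0-fold lower number from compound 1 to compound 2 (0.48 log units; beyond the scatter), was modest and replaced 2-carboxypiperidin-1-yl with (2-acetamidoethyl)amino. Compound 3 again carries a carboxy group, so a similar move toward a higher number is expected in this assay, though one step is thin evidence. The expected change is a 2.2-fold higher number from compound 2 to compound 3 (0.35 log units; beyond the scatter). Compound 3 is estimated at 4000 nM, within a range of 1500 nM to 12000 nM.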

Compound 3, half-maximal inhibitory concentration: > 10000 nM
Compound 3 ended at the assay's limit; the forecaster's own chance of this, stated with the estimate: 3%; middle value at least 2.5-fold (0.39 log units) from the limit.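

In this assay compound 3 gives > 10000 nM, which is a limit of the assay and not a number. On the amine nitrogen, 1-carboxy-2-hydroxypropyl gives weaker inhibition than 2-acetamidoethyl, with an at least 5.5-fold higher number from compound 2 to compound 3 (0.74 log units; beyond the scatter), and this size is only a floor. Against 2-carboxypiperidin-1-yl the change reads an at least 1.8-fold higher number from compound 1 to compound 3 (0.26 log units; that floor lies within the scatter), so these two carboxy-bearing amines cannot be ranked.

As far as these compounds go, the true size of the loss remains open. So does the question of whether a methyl ester in place of the carboxylic acid, or a plain 2-hydroxyethyl chain, would keep the number of compound 2.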